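A Nitro Group Added to Two Related Amides

The compounds below may be only part of what the source reports. "The series", "measured", "known", "first", "only" and "open" are said of these compounds alone.

Compound 1 (`COc1cc(NC(=O)c2ccc(Cl)cc2)ccc1NS(=O)(=O)C(F)(F)F`): 108000 nM in an ADME assay on RAW264.7 cells (Mus musculus) for cytotoxicity, read by MTT assay, with a stated time of 48 h; a lower number here means a stronger inhibitor, a higher number a weaker inhibitor.
Compound 2 (`COc1cc(NC(=O)c2ccc(Cl)c([N+](=O)[O-])c2)ccc1NS(=O)(=O)C(F)(F)F`) reaches only a limit of this assay, > 250000 nM.
Compound 3 (`CS(=O)(=O)Nc1ccc(NC(=O)c2ccc(Cl)cc2)cc1Cl`): 79900 nM in this assay.

Compound 1 and compound 3 lie within the usual scatter of each other. Compound 2 differs from compound 1 by nitro in place of hydrogen on an aromatic carbon, and that change gave an at least 2.3-fold higher number from compound 1 to compound 2 (0.36 log units; beyond the scatter), the step running up to the limit of > 250000 nM in this assay, at which 1 of the 3 values shown sits. Compound 4, `CS(=O)(=O)Nc1ccc(NC(=O)c2ccc(Cl)c([N+](=O)[O-])c2)cc1Cl`, has not been measured; it differs from compound 3 by the same change, (nitro in place of hydrogen on an aromatic carbon). The difference between the cores of compound 1 and compound 3 is not broken down here. For compound 4 a step of a 2.5-fold higher number from compound 3 to compound 4 (0.40 log units; beyond the scatter) is expected, because the same change gave an at least 2.3-fold higher number from compound 1 to compound 2 (0.36 log units; beyond the scatter). Compound 4 is estimated at 200000 nM, within a range from 100000 nM to 450000 nM, and a limit rather than a number is a real possibility.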

Compound 4, half-maximal inhibitory concentration: 43600 nM
Beside the measured number, compound 4's estimate is 4.6-fold (0.66 log units) above it, outside the stated range (below it).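

In this assay, going by these compounds alone, adding the nitro group gave a 1.8-fold lower number from compound 3 to compound 4 (0.26 log units; within the scatter), so on this core the change produces no step that can be told apart from the scatter. Going by these compounds, the change therefore did not carry over from one core to the other with the same result, as the two steps differ: the same change on two cores in this assay, an at least 2.3-fold higher number (0.36 log units; beyond the scatter) from compound 1 to compound 2 and a 1.8-fold lower number (0.26 log units; within the scatter) from compound 3 to compound 4, at least 4.2-fold (0.62 log units) apart, beyond the scatter of two such steps Compound 2's > 250000 nM is a limit, not a number, so the full size of its step remains unknown, and a single pair of cores cannot show which structural difference matters.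

The compounds shown leave open whether a nitrile or an amine in place of the nitro group would also behave differently on the two cores. They also leave open whether the gap follows the methoxy group or the trifluoromethyl group of compound 1.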